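Lengthening the Hydroxycarbamoyl Chain in a Weak Series

A few compounds are considered here, and "the series" means these few. Any claim that something is new, unique, unknown or untested is made for them only; others in the source may bear on it.

Compound 2 `CC(C)CCN(CCCCCC(=O)NO)c1ncc(C(=O)NCCCn2ccnc2)s1` is one of three compounds tested in a functional assay on HCT-116 cells (Homo sapiens) for inhibition, read by MTT assay, with a stated time of 72 h; on this read-out lower numbers stand for stronger inhibition and higher numbers for weaker inhibition. In this assay compound 2 gives 85000 nM, the second highest of the three numbers; compound 1 `O=C(NO)c1ccc(CN(Cc2ccc(F)cc2)c2ncc(C(=O)NCCCn3ccnc3)s2)cc1` gives 99000 nM, and compound 3 `O=C(CCCCCCCN(Cc1ccc(F)cc1)c1ncc(C(=O)NCCCn2ccnc2)s1)NO` gives 63000 nM. All three numbers lie within the usual scatter of one another, so none of these compounds can be called stronger or weaker than the rest. Compound 4 `CC(C)CCN(CCCCCCC(=O)NO)c1ncc(C(=O)NCCCn2ccnc2)s1` has not yet been measured. It differs from compound 2 in one place: (hydroxycarbamoyl)methyl in place of hydroxycarbamoyl on a saturated chain carbon, five bonds along the chain from a nitrogen on an aromatic ring.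

Among the compounds with values here, only one measured step exists, and it does not test this kind of change: a 1.6-fold lower number from compound 1 to compound 3 (0.20 log units; within the scatter) replaces a ring-bearing group with a chain-bearing one, rather than going from hydroxycarbamoyl to (hydroxycarbamoyl)methyl. Within the data shown here, no measured pair shows what that particular change does. With so little to go on, and with the three measured numbers sitting so close together, the expected result for compound 4 in this assay is a step of a 1.1-fold lower number from compound 2 to compound 4 (0.05 log units; within the scatter), that is, nothing beyond the scatter. Compound 4 is therefore estimated at 75000 nM, with a range from 30000 nM to 200000 nM.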

Compound 4, half-maximal inhibitory concentration: 30000 nM
Compound 4: middle estimate off by 2.5-fold (0.40 log units), on the high side, within the range that was stated.
By their numbers in this assay, from the lowest: compound 4; then compounds 3, 2 and 1 (each within the scatter of the next).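

In this assay, putting (hydroxycarbamoyl)methyl in place of hydroxycarbamoyl, on a saturated chain carbon five bonds along the chain from a nitrogen on an aromatic ring, gives a 2.8-fold lower number from compound 2 to compound 4 (0.45 log units; beyond the scatter). Within the data shown here, this is the first change to move the number past the usual spread of repeat measurements, whereas the only earlier step, a 1.6-fold lower number from compound 1 to compound 3 (0.20 log units; within the scatter), swapped a ring-bearing group for a chain-bearing one and stayed within it, so the length of this chain does matter here, though only modestly, and on this single pair. Nothing measured here accounts for the gain in terms of any property of the chain.

On these data alone, what remains open is how far the trend runs: a longer chain, ending in 2-(hydroxycarbamoyl)ethyl at this same place, might lower the number further or might raise it again. It is also unknown whether the hydroxycarbamoyl end itself is needed, which a carboxylic acid at the end of the same chain would test.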